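Growing an Aryl Tail on a Small Amine Core

The source may hold more compounds than are shown below. What is called first, only, known or untested is meant among the compounds shown, and "the series" means these compounds.

Measured so far:
- compound 1, `COc1ccc2c(c1)[C@@H](O)CN(C)C2`: > 100000 nM
- compound 2, `CN1Cc2ccc(OCc3ccc([N+](=O)[O-])cc3)cc2[C@@H](O)C1`: > 50000 nM
- compound 3, `CN1Cc2ccc(OCc3ccc(Oc4ccc(F)cc4)cc3)cc2[C@@H](O)C1`: 5600 nM

The three compounds share one core and differ only in what hangs from the oxygen on its aromatic ring. In an ADME assay on Vero cells (Chlorocebus sabaeus) for cytotoxicity, read by sulforhodamine B assay, with a stated time of 72 h (a higher number here means a weaker inhibitor, a lower number a stronger inhibitor), compound 1 gives > 100000 nM, and this is a limit of the assay rather than a number. Compound 2 also sits at a limit, > 50000 nM. Going by the values given here, compound 3 gives 5600 nM, the only plain number among the three. Among the compounds with values here, the one measured step is an at least 8.9-fold lower number from compound 2 to compound 3 (0.95 log units; beyond the scatter). For compound 1 the numbers show only (the limit of > 100000 nM in this assay, at which 1 of the 3 values shown sits).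

Compound 4, `CN1Cc2ccc(OCc3ccc(Br)cc3)cc2[C@@H](O)C1`, is not yet measured. It differs from compound 1 as follows: 4-bromophenyl in place of hydrogen on a saturated chain carbon bound to an oxygen on an aromatic ring. Within the data shown here, no measured step covers this exact change. Compound 2 carries a related tail and stays at a limit, while the larger tail of compound 3 brought the number down; the bromine-bearing tail of compound 4 lies between these two in size. The step of an at least 2.5-fold lower number from compound 1 to compound 4 (0.39 log units; beyond the scatter) is therefore expected to be small or absent beyond the scatter, with a fair chance of another limit. Compound 4 is estimated at 40000 nM, within 10000 nM to 100000 nM.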

Compound 4, half-maximal inhibitory concentration: 37000 nM
Estimate against measurement, compound 4: 1.1-fold (0.03 log units) above; the measured number falls inside the stated range.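

Compound 4 shows that the 4-bromophenyl alone, on a saturated chain carbon bound to an oxygen on an aromatic ring, is enough to bring a plain number in this assay, with an at least 2.7-fold lower number from compound 1 to compound 4 (0.43 log units; beyond the scatter). The tail need not carry the second aromatic ring of compound 3 for a number to appear, yet that ring still counts: bromo in place of 4-fluorophenoxy gives a 6.6-fold higher number from compound 3 to compound 4 (0.82 log units; beyond the scatter). Bromo in place of nitro gives an at least 1.3-fold lower number from compound 2 to compound 4 (0.13 log units; that floor lies within the scatter), which cannot be read as a real change, for the value of compound 2 is a limit and not a number: the limit of > 50000 nM in this assay, at which 1 of the 4 values shown sits.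

On these data alone, what remains open is whether the number in this assay follows the size of the tail or the identity of the group at its end, as bromo, nitro and 4-fluorophenoxy differ in both respects. A carboxylic acid, an amine or a longer chain in that same place would give further points for separating these two readings, which three tails alone cannot do.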